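The compounds below may be only part of what the source reports. "The series", "measured", "known", "first", "only" and "open" are said of these compounds alone.

Working notes on the series. In a physicochemical assay for lipophilicity, read by HPLC, at pH 7.5 (on this read-out lower numbers stand for lower lipophilicity and higher numbers for higher lipophilicity), compound 1 (`N#Cc1c(-c2ccc(Br)cc2)nc2cnccc2c1NCC(N)=O`) gives 1.9, compound 2 (`CC[C@@H](Nc1c(C#N)c(-c2ccc(-c3ccncc3C)cc2)nc2cnccc12)C(N)=O`) gives 2 and compound 3 (`CCOc1ccccc1-c1ccc(-c2nc3cnccc3c(C[C@H](C)C(=O)O)c2C#N)cc1`) gives 2.2, so compound 1 stands within the scatter of both others. Compound 4 (`CC(C)(CC(N)=O)c1c(C#N)c(-c2ccc(Br)cc2)nc2cnccc12`) keeps the core of compound 1 and changes one place, on an aromatic carbon ortho to a cyano group and opposite the ring nitrogen: a group of 7 heavy atoms (5 carbon, 1 nitrogen, 1 oxygen; no ring) in place of a group of 5 heavy atoms (2 carbon, 2 nitrogen, 1 oxygen; no ring), on an aromatic carbon. Among the compounds with values here, no measured step covers this kind of change, so the expectation rests on the structural change alone: a higher number in this assay, probably beyond the scatter. The estimated step is a number 0.60 log units higher from compound 1 to compound 4 (beyond the scatter). For compound 4 the expected value is 2.5, with an estimated range of 2.1 to 3.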

Compound 4, distribution coefficient: 2.1
Estimate against measurement, compound 4: 0.40 log units above; the measured number falls inside the stated range.
By their numbers in this assay, from the lowest: compounds 1, 2, 4 and 3 (each within the scatter of the next).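

At this position, on an aromatic carbon ortho to a cyano group and opposite the ring nitrogen, the entering group in place of (carbamoylmethyl)amino gives a number 0.20 log units higher from compound 1 to compound 4 (within the scatter) in this assay on the shared core. This read-out therefore does not separate the two groups here, despite the larger group and the loss of the linking nitrogen at the aromatic carbon. On these data alone, whether a primary amine or a longer chain in place of the terminal amide would also stay within the scatter of compound 1 remains open. Nothing available bears on the reason for this result.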